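A few compounds are considered here, and "the series" means these few. Any claim that something is new, unique, unknown or untested is made for them only; others in the source may bear on it.

Among the compounds with values here, compound 2 `COc1ccccc1-c1cn(C[C@H](O)[C@H]2OC(=O)C(OCc3ccccc3)=C2OCc2ccccc2)nn1` is one of only two compounds that have a result so far. In a functional assay on SW-620 cells (Homo sapiens) for antiproliferative activity, read by MTT assay, with a stated time of 72 h (a lower number here means a stronger inhibitor, a higher number a weaker inhibitor), compound 2 gives > 100000 nM, which is a limit of the assay rather than a number, so its standing on the scale is not fixed. Compound 1 `O=C1O[C@H]([C@@H](O)Cn2cc(-c3cccc(O)c3)nn2)C(OCc2ccccc2)=C1OCc1ccccc1` carries 3-hydroxyphenyl where compound 2 carries 2-methoxyphenyl. In this assay compound 1 gives > 100000 nM, again a limit. The step from compound 1 to compound 2 is a step that the two limits leave unreadable from compound 1 to compound 2. Compound 3 `CCCCCCCCCCc1cn(C[C@H](O)[C@H]2OC(=O)C(OCc3ccccc3)=C2OCc2ccccc2)nn1` has not been measured; it differs from compound 2 by decyl in place of 2-methoxyphenyl on an aromatic carbon. Within the data shown here, the only measured step that could bear on this change is a step that the two limits leave unreadable from compound 1 to compound 2, and it gives no guidance, since both results sit at the limit of > 100000 nM in this assay, at which 2 of the 2 values shown sit. With nothing readable to build on, compound 3 is expected near 80000 nM, within 10000 nM to 300000 nM. That estimate corresponds to an expected step of an at least 1.2-fold lower number from compound 2 to compound 3 (0.09 log units; that floor lies within the scatter).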

Compound 3, half-maximal inhibitory concentration: 45200 nM
The estimate for compound 3 lay 1.8-fold (0.25 log units) above the measured number, within the range that was stated.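

In this assay, within the data shown here, decyl on the aromatic carbon of the five-membered ring gives the first readable change at this position: an at least 2.2-fold lower number from compound 2 to compound 3 (0.34 log units; beyond the scatter), and likewise an at least 2.2-fold lower number from compound 1 to compound 3 (0.34 log units; beyond the scatter). Both steps are floors rather than full sizes, and they show that a group with no ring can replace either substituted phenyl here and still give a measurable value. The step between the two phenyl-bearing compounds still cannot be read, so the earlier pair offers no ranking of its own: the limit of > 100000 nM in this assay, at which 2 of the 3 values shown sit.

The compounds shown leave open whether the lower number follows from the chain itself or from the loss of the aromatic ring. They also leave open how a shorter alkyl chain, a longer chain or an amine at this position would compare with decyl.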